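The source may hold more compounds than are shown below. What is called first, only, known or untested is meant among the compounds shown, and "the series" means these compounds.

Among the measured compounds shown here, compound 1 `CCOc1nc(CC)n2c1C(CCc1ccc(C(F)(F)F)cc1)N([C@@H](C(=O)NC)c1ccccc1)CC2` is tested in a functional assay on CHO cells for antagonist activity at Orexin receptor type 2 (Homo sapiens), read by FLIPR and calcium flux (on this read-out higher numbers stand for weaker inhibition and lower numbers for stronger inhibition), and gives 2750 nM, the highest of the two numbers measured so far. Compound 2 `CCc1nc(SC)c2n1CCN([C@@H](C(=O)NC)c1ccccc1)[C@H]2CCc1ccc(C(F)(F)F)cc1` differs from compound 1 in several places at once. In this assay compound 2 gives 14 nM, showing that the shared core can reach much stronger inhibition. Compound 3 `CCc1nc(C(=O)N(C)C)c2n1CCN([C@@H](C(=O)NC)c1ccccc1)C2CCc1ccc(C(F)(F)F)cc1` carries dimethylcarbamoyl in place of ethoxy on an aromatic carbon. Compound 3 is expected to reach about 500 nM, somewhere between 60 nM and 4000 nM. For the measured compounds named here, the expected step from compound 1 to compound 3, a 5.5-fold lower number from compound 1 to compound 3 (0.74 log units; beyond the scatter), is a move toward stronger inhibition that goes beyond the usual scatter, although the data give no directly comparable pair to anchor it.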

Compound 3, half-maximal inhibitory concentration: 111 nM
Compound 3: the middle estimate sits 4.5-fold (0.65 log units) above what was measured; measured number inside the range.
By their numbers in this assay, from the lowest: compound 2; then compound 3; then compound 1.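

In this assay, dimethylcarbamoyl in place of ethoxy on this aromatic carbon gives a 25-fold lower number from compound 1 to compound 3 (1.39 log units; beyond the scatter), a large move toward stronger inhibition from a change in one place. This shows that the group on this carbon strongly affects the read-out, and that a carbonyl-bearing group fits this position better than ethoxy. No measurement at hand accounts for the drop. As far as these compounds go, it remains open whether the carbonyl or the methyl groups on the amide nitrogen matter more. A primary amide, a carboxylic acid or a simple amine on this carbon would help separate these.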